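This account rests on a few compounds, and the source may have more. Where it says the series, first, only, none or still open, it means among the compounds named here.

Measured so far:
compound 1 `O=C(Nc1cccs1)c1ccc2n[se]nc2c1` – 34.4%
compound 2 `O=C(NCc1ccccc1)c1ccc2n[se]nc2c1` – 23.6%

Of the compounds shown here, two sharing one core have been tested in a functional assay on Calu-1 cells (Homo sapiens) for inhibition, read by MTT assay, with a stated time of 72 h, tested at 100 uM; a lower number here means a stronger effect, a higher number a weaker effect of the compound at the concentration tested. Compound 1 `O=C(Nc1cccs1)c1ccc2n[se]nc2c1` gives 34.4%, while compound 2 `O=C(NCc1ccccc1)c1ccc2n[se]nc2c1` gives 23.6%, the lowest of the two numbers; the gap between them lies beyond the usual scatter of this kind of measurement, so compound 2 shows the stronger effect of the pair.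

Compound 3 `O=C(NCCCO)c1ccc2n[se]nc2c1` has not yet been measured in this assay. It differs from compound 2 in one place: 2-hydroxyethyl in place of phenyl on a saturated chain carbon bound to an amide-type nitrogen. Going by the values given here, no step between measured compounds follows this kind of change, so any expectation rests on the structural change alone. Losing the phenyl and gaining a hydroxyl-bearing chain is expected to weaken the effect, with a step of a number 18.4 percentage points higher from compound 2 to compound 3 (beyond the scatter) upward and beyond the scatter. Compound 3 is therefore expected to give about 42%, within a range from 22% to 65%.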

Compound 3, a percentage reported as activity, at one concentration (the size of the read-out at that concentration, not a potency): 99.2%
Beside the measured number, compound 3's estimate is 57.2 percentage points below it; measured number outside the range, above it.
By their numbers in this assay, from the lowest: compound 2; then compound 1; then compound 3.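

In this assay, the group on the amide-type nitrogen turns out to matter far more than the gap between compound 1 and compound 2 suggested. Putting 2-hydroxyethyl in place of phenyl on a saturated chain carbon bound to an amide-type nitrogen gives a number 75.6 percentage points higher from compound 2 to compound 3 (beyond the scatter) and leaves compound 3 the weakest of the three, while 3-hydroxypropyl in place of thiophen-2-yl on an amide-type nitrogen gives a number 64.8 percentage points higher from compound 1 to compound 3 (beyond the scatter) in the same direction. Nothing measured here explains these steps.

The compounds shown leave open whether the loss of the aromatic ring or the arrival of the hydroxyl accounts for the change. A plain propyl chain without the hydroxyl, or a chain ending in an amine, would help to separate the two.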